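Swapping a cycloheptyl amide for a pyridylmethyl amide

This account rests on a few compounds, and the source may have more. Where it says the series, first, only, none or still open, it means among the compounds named here.

Measured compounds:
- compound 1 `CO[C@H]1CC[C@H](NC(=O)c2n[nH]cc2NC(=O)c2cnc3ccccn23)CC1`: 5900 nM
- compound 2 `COc1cccc(OC)c1C(=O)Nc1c[nH]nc1C(=O)NC1CCCCCC1`: 42000 nM
- compound 3 `CO[C@H]1CC[C@H](NC(=O)c2n[nH]cc2NC(=O)c2cc3ccccn3n2)CC1`: 1000 nM

In an ADME assay on MRC5 cells (Homo sapiens) for inhibition, with a stated time of 72 h (a higher number here means that more compound is needed for the effect, a lower number that less compound is needed), compound 2 gives 42000 nM, the highest of the three numbers. Compound 1 lies closer to it, with 5900 nM, while compound 3, at 1000 nM, lies furthest away. Going by the values given here, the one step that connects two measured compounds in one place is a 5.9-fold lower number from compound 1 to compound 3 (0.77 log units; beyond the scatter); it exchanges one bicyclic group for another on a carbonyl carbon of the shared core.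

Compound 4 `COc1cccc(OC)c1C(=O)Nc1c[nH]nc1C(=O)NCc1ncccc1C` is derived from compound 2 by the change ((3-methylpyridin-2-yl)methyl in place of cycloheptyl on an amide-type nitrogen). Among the compounds with values here, this change sits on the amide-type nitrogen whose other neighbour is a carbonyl carbon, a different position from the one altered between compound 1 and compound 3, so that step does not bear on it, and no measured pair shows what replacing cycloheptyl by (3-methylpyridin-2-yl)methyl does. The data therefore give no direction for this assay. Compound 4 is expected to stay near compound 2, with a step of a 1.4-fold lower number from compound 2 to compound 4 (0.15 log units; within the scatter) that may well lie within the scatter. The estimate for compound 4 is 30000 nM, within a range of 8000 nM to 100000 nM.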

Compound 4, half-maximal effective concentration: > 50000 nM
Compound 4 ended at the assay's limit (the forecaster's own chance of this, stated with the estimate: 15%); middle value at least 1.6-fold (0.22 log units) away from the limit.
By their numbers in this assay, from the lowest: compound 3; then compound 1; then compound 2. At a limit, above all of these: compound 4.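

In this assay, going by these compounds alone, the exchange of cycloheptyl for (3-methylpyridin-2-yl)methyl on the amide-type nitrogen gives the first reading at this position: an at least 1.1-fold higher number from compound 2 to compound 4 (0.07 log units; that floor lies within the scatter). Compound 4 gives > 50000 nM, which is a limit of the assay and not a number, and it is the only value of this kind among those shown: the limit of > 50000 nM in this assay, at which 1 of the 4 values shown sits. The floor of the step lies within the scatter, so the result shows that this exchange produced no lower number for compound 4 than for compound 2, but it does not fix the size of the step or establish a real rise.

From the compounds shown here alone, it remains open which part of the entering group matters, as the ring nitrogen, the methyl and the methylene link all enter together, while the seven-membered ring leaves; a benzyl group or a cyclopentyl group on the same nitrogen would help to separate these parts. Going by these compounds, it is also open how the methoxycyclohexyl group of compound 1 and compound 3 would read on this nitrogen with the dimethoxybenzoyl side of compound 2 kept in place.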